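Bromo to Chloro Exchange on Two Related Ring Systems

This account rests on a few compounds, and the source may have more. Where it says the series, first, only, none or still open, it means among the compounds named here.

This account concerns four compounds that share the same atoms arranged in two different ways. Compound 1 `COC(=O)[C@@]1(C)CCC=C2[C@@H]1CC[C@@H](C)[C@]2(C)Cc1c[nH]c2ccc(Br)cc12` and compound 2 `COC(=O)[C@@]1(C)CCC=C2[C@@H]1CC[C@@H](C)[C@]2(C)Cc1c[nH]c2ccc(Cl)cc12` carry one core; compound 3 `COC(=O)[C@@]1(C)CC[C@@H]2C3=C1CC[C@@H](C)[C@]3(C)C[C@@H]1c3cccc(Br)c3N[C@H]21` and compound 4 `COC(=O)[C@@]1(C)CC[C@@H]2C3=C1CC[C@@H](C)[C@]3(C)C[C@@H]1c3cccc(Cl)c3N[C@H]21` carry another. The difference between the two cores is not broken down here.

In a functional assay on SW1573 cells (Homo sapiens) for inhibition, read by sulforhodamine B assay, with a stated time of 48 h (on this read-out lower numbers stand for stronger inhibition of growth and higher numbers for weaker inhibition of growth), compound 1 gives 12000 nM, and compound 2 gives 11000 nM. The change between them, (chloro in place of bromo on an aromatic carbon), produced a 1.1-fold lower number from compound 1 to compound 2 (0.04 log units; within the scatter). Compound 3 gives 44000 nM in this assay, the highest number of the three measured compounds, and its gap to compound 1 and to compound 2 lies beyond the scatter.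

Compound 4 arises from compound 3 by the same kind of change, (chloro in place of bromo on an aromatic carbon). The surroundings of the place differ: in compound 1 the carbon belongs to a fused system of two rings and sits meta and para to a fused ring, whereas in compound 3 it belongs to a fused system of five rings and sits ortho and meta to a fused ring.

Because the earlier exchange gave a 1.1-fold lower number from compound 1 to compound 2 (0.04 log units; within the scatter), the step from compound 3 to compound 4 is expected to be similarly small, a 1.1-fold lower number from compound 3 to compound 4 (0.04 log units; within the scatter). Compound 4 is therefore estimated to give 40000 nM in this assay, with a likely range from 20000 nM to 90000 nM.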

Compound 4, concentration for 50% growth inhibition: 49000 nM
Estimate against measurement, compound 4: 1.2-fold (0.09 log units) below; the measured number falls inside the stated range.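

In this assay, chloro in place of bromo gave a 1.1-fold higher number from compound 3 to compound 4 (0.05 log units; within the scatter), so on this second core, as on the first, the two halogens could not be told apart. Set side by side, the two steps show no difference in how the change behaves on the two cores: the same change on two cores in this assay, a 1.1-fold lower number (0.04 log units; within the scatter) from compound 1 to compound 2 and a 1.1-fold higher number (0.05 log units; within the scatter) from compound 3 to compound 4, 1.2-fold (0.08 log units) apart, within the scatter of two such steps. Among these compounds, this shows only that an exchange with no readable effect on one core also had no readable effect on the other; it does not show that a change producing a larger step would carry across in the same way, and with just two pairs of compounds in one cell assay, it establishes no general rule for the series.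

The compounds shown carry only bromo or chloro at this place, so what a fluoro group, a methoxy group or an amine would do there on either core remains open. Equally open, from the compounds shown here alone, is how either core would respond if a carboxylic acid or an amide stood in place of the methyl ester shared by all four compounds.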